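The source may report more compounds than this note shows. Statements on the series, on what has been measured and on what is new or still open speak of the compounds shown alone.

Compound 1 `CCCN(CCC)c1nc(C(C)(C)C)ccc1CNC(=O)C(C)c1ccc(NS(C)(=O)=O)c(F)c1` and compound 2 `CC(C(=O)NCc1ccc(C(C)(C)C)cc1N1CCCCC1)c1ccc(NS(C)(=O)=O)c(F)c1` share the same amide and sulfonamide portion and differ in the remainder of the core. In an assay on cells for antagonist activity at transient receptor potential cation channel subfamily V member 1 (Homo sapiens), read by FLIPR and calcium flux, with a stated time of 6 min (a higher number here means a weaker inhibitor, a lower number a stronger inhibitor), compound 1 gives 2.5 nM, while compound 2 gives 1.9 nM. Compound 2 holds the lower of the two numbers, yet its gap to compound 1 lies within the scatter, so the two cannot be ranked. Compound 3 `CC(C(=O)NCc1ccc(C(C)(C)C)cc1OCC(C)(C)C)c1ccc(NS(C)(=O)=O)c(F)c1` carries neopentyloxy in place of piperidin-1-yl on an aromatic carbon. Among the measured compounds shown here, no measured pair shows this change, so the step of a 2.1-fold higher number from compound 2 to compound 3 (0.32 log units; beyond the scatter) is expected to be modest, at most a little beyond the scatter toward a higher number. Compound 3 is therefore estimated at 4 nM, within a range of 1.5 nM to 12 nM.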

Compound 3, inhibition constant: 3.8 nM
Compound 3: the middle estimate sits 1.1-fold (0.02 log units) above what was measured; the measured number falls inside the stated range.
By their numbers in this assay, from the lowest: compounds 2, 1 and 3 (each within the scatter of the next).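

On an aromatic carbon ortho to a large group, neopentyloxy in place of piperidin-1-yl gives a 2.0-fold higher number from compound 2 to compound 3 (0.30 log units; within the scatter) in this assay and so leaves the two groups unranked. At this position, then, an open chain joined through oxygen reads like a ring joined through nitrogen. No evidence bearing on this result is available. The compounds shown leave open whether a much smaller group on this carbon, such as methoxy or fluorine, would keep the value, and whether an amine carrying a hydrogen would.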